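The source may hold more compounds than are shown below. What is called first, only, known or untested is meant among the compounds shown, and "the series" means these compounds.

Two small compounds that share a core open the series. Compound 1 `CSc1nc2c(C)nsc2[nH]1` is measured in a functional assay on HFF cells (Homo sapiens) for inhibition (on this read-out higher numbers stand for weaker inhibition and lower numbers for stronger inhibition), and gives 26000 nM. Compound 2 `CSc1nc2cnsc2[nH]1` carries the change hydrogen in place of methyl on an aromatic carbon relative to compound 1, and in this assay compound 2 gives 32000 nM. The step of a 1.2-fold higher number from compound 1 to compound 2 (0.09 log units; within the scatter) shows that this change left the read-out essentially where it was.

Compound 3 `Cc1nsc2c1nc(SCc1ccccc1)n2[C@H]1C[C@H](O)[C@@H](CO)O1` is a larger molecule in which a further group is attached to the core; how its core differs from the core of compound 1 is not broken down here. In this assay compound 3 gives > 100000 nM, and this is a limit of the assay rather than a number (the limit of > 100000 nM in this assay, at which 1 of the 3 values shown sits).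

Compound 4 `OC[C@H]1O[C@@H](n2c(SCc3ccccc3)nc3cnsc32)C[C@@H]1O` has not yet been measured. It differs from compound 3 by hydrogen in place of methyl on an aromatic carbon, which is the same change that separates compound 1 from compound 2. The step expected for compound 4 is a step that the limit leaves unreadable from compound 3 to compound 4, and this rests on the outcome of a 1.2-fold higher number from compound 1 to compound 2 (0.09 log units; within the scatter). Compound 4 is therefore estimated at 150000 nM in this assay. Its expected range runs from 60000 nM to 400000 nM, and there is a real chance that the assay again reports only a limit for compound 4.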

Compound 4, half-maximal inhibitory concentration: > 100000 nM
Compound 4: only a limit was reported (the forecaster's own chance of this, stated with the estimate: 75%); the middle value does not contradict the limit.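

Compound 3 and compound 4 both reach only a limit in this assay, so no step between them can be read: the limit of > 100000 nM in this assay, at which 2 of the 4 values shown sit.

The compounds shown leave open how strongly compound 3 and compound 4 inhibit in this assay, and whether hydrogen in place of methyl on an aromatic carbon matters as little in these larger molecules as it does between compound 1 and compound 2.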